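Oxime amide replacing carbamoyl on an anilide chain

The source may hold more compounds than are shown below. What is called first, only, known or untested is meant among the compounds shown, and "the series" means these compounds.

compound 1, `NC(=O)C(=O)NCCCCC(=O)Nc1ccccc1`: > 100000 nM in a functional assay on HCT-116 cells (Homo sapiens) for inhibition, read by colorimetric assay, with a stated time of 3 days; a higher number here means a weaker inhibitor, a lower number a stronger inhibitor
compound 2, `O=C(CCCCCCNC(=O)C(O)(O)C(F)(F)F)Nc1cccc(Br)c1`: 3060 nM in this assay

Compound 1 stands at the limit of > 100000 nM in this assay, at which 1 of the 2 values shown sits, which is a limit of the assay and not a number. Within the data shown here, compound 2 gives a measured number, but no single-change step joins it to compound 1, so the two values show only that one compound falls within the measured range and the other does not. Compound 3, `C/C(=N\O)C(=O)NCCCCC(=O)Nc1ccccc1`, differs from compound 1 by a group of 4 heavy atoms (2 carbon, 1 nitrogen, 1 oxygen; no ring) in place of a group of 3 heavy atoms (1 carbon, 1 nitrogen, 1 oxygen; no ring), on a carbonyl carbon. Among the measured compounds shown here, no measured step of this kind exists, so only a modest move toward stronger inhibition, if any beyond the scatter, is expected: an at least 1.2-fold lower number from compound 1 to compound 3 (0.09 log units; that floor lies within the scatter). Compound 3 is estimated at 80000 nM, between 25000 nM and 250000 nM.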

Compound 3, half-maximal inhibitory concentration: > 100000 nM
Compound 3: no number, only a limit; the forecaster's own chance of this, stated with the estimate: 60%; middle value at least 1.2-fold (0.09 log units) away from the limit.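

Compound 1 and compound 3 both give only a limit and not a number, so no step can be read between them: the limit of > 100000 nM in this assay, at which 2 of the 3 values shown sit. From the compounds shown here alone, whether replacing the carbamoyl in compound 1 changes inhibition at all stays open.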